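The source may hold more compounds than are shown below. What is called first, only, known or untested is meant among the compounds shown, and "the series" means these compounds.

Working notes on the series. In a functional assay on KB cells (Homo sapiens) for antiproliferative activity, read by sulforhodamine B assay, with a stated time of 3 days (on this read-out higher numbers stand for an effect only at larger amounts of compound and lower numbers for an effect already at smaller amounts), compound 1 `CCC1=C(O)c2c(oc(-c3ccc(C(C)C)cc3)cc2=O)C(CC)(CC)C1=O` gives 8.13 uM, compound 2 `CCC1=C(O)c2c(oc(-c3ccc(CC(C)C)cc3)cc2=O)C(CC)(CC)C1=O` gives 29.3 uM, and compound 3 `CCC1=C(O)c2c(oc(-c3ccc(F)cc3)cc2=O)C(CC)(CC)C1=O` gives 33 uM. On these three numbers compound 2 stands second highest: its gap to compound 3 is a 1.1-fold higher number from compound 2 to compound 3 (0.05 log units; within the scatter), while compound 1 sits lower by a 3.6-fold higher number from compound 1 to compound 2 (0.56 log units; beyond the scatter), and a 4.1-fold higher number from compound 1 to compound 3 (0.61 log units; beyond the scatter) points the same way. Compound 4 `CCC1=C(O)c2c(oc(-c3ccc(COC)cc3)cc2=O)C(CC)(CC)C1=O` carries methoxy in place of isopropyl on a saturated chain carbon bound to an aromatic carbon. Among the compounds with values here, no measured step in this assay touches an oxygen-bearing group on the aryl chain, so the change has no direct precedent; the two steps that do bear on it show a move within the scatter once the chain leaves isopropyl. The expected step from compound 2 to compound 4 is therefore a 1.2-fold lower number from compound 2 to compound 4 (0.07 log units; within the scatter), at most modest in either direction. Compound 4 is estimated at 25 uM, range 8 uM to 70 uM.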

Compound 4, concentration for half-maximal effect: > 52.4 uM
Compound 4: no number, only a limit; the forecaster's own chance of this, stated with the estimate: 5%; at least 2.0-fold (0.32 log units) between middle value and limit.
By their numbers in this assay, from the lowest: compound 1; then compounds 2 and 3 (each within the scatter of the next). At a limit, above all of these: compound 4.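

In this assay compound 4 gives only a limit, > 52.4 uM, the one such reading among these compounds: the limit of > 52.4 uM in this assay, at which 1 of the 4 values shown sits. Methoxymethyl on the aromatic carbon does not recover the reading of isopropyl, with an at least 6.4-fold higher number from compound 1 to compound 4 (0.80 log units; beyond the scatter). The other two steps, an at least 1.7-fold higher number from compound 2 to compound 4 (0.25 log units; that floor lies within the scatter) and an at least 1.5-fold higher number from compound 3 to compound 4 (0.20 log units; that floor lies within the scatter), have floors within the scatter, so they do not separate compound 4 from the isobutyl and fluoro compounds.

From the compounds shown here alone, how far past its limit compound 4 truly lies stays open. So does how an amine, a carboxylic acid or a longer ether chain would read on the same aromatic carbon.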